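Replacing 2,6-dimethylphenyl with 1,3-thiazol-2-yl in the series

This account rests on a few compounds, and the source may have more. Where it says the series, first, only, none or still open, it means among the compounds named here.

In a functional assay on KB cells (Homo sapiens) for cytotoxicity (on this read-out higher numbers stand for an effect only at larger amounts of compound and lower numbers for an effect already at smaller amounts), compound 1 `COC1=C(C)C(=O)/C(=C(O)/C=C/c2ccc(OC)cc2)C(=O)C1(C)C` gives 3.6 ug/mL and compound 2 `COC1=C(C)C(=O)/C(=C(O)/C=C/c2ccc(O)cc2)C(=O)C1(C)C` gives 3.8 ug/mL while compound 3 `COC1=C(C)C(=O)/C(=C(O)/C=C/c2c(C)cccc2C)C(=O)C1(C)C` gives 7.1 ug/mL on the same read-out. Compound 3 therefore stands within the scatter of both other compounds, and the three numbers cannot be ranked.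

Compound 4 `COC1=C(C)C(=O)/C(=C(O)/C=C/c2nccs2)C(=O)C1(C)C` has 1,3-thiazol-2-yl in place of 2,6-dimethylphenyl on a double-bonded chain carbon bound to a double-bonded chain carbon and awaits measurement.

Two measured steps exchange the group at that same place, namely a 2.0-fold higher number from compound 1 to compound 3 (0.29 log units; within the scatter) and a 1.9-fold higher number from compound 2 to compound 3 (0.27 log units; within the scatter) and neither leaves the scatter. The step of a 1.1-fold higher number from compound 1 to compound 2 (0.02 log units; within the scatter) concerns an oxygen on an aromatic ring and bears on the change only indirectly. Going by the values given here, no measured compound carries a five-membered aromatic ring, so these steps are a limited guide to the new group. Going by the two exchanges at this place, the step expected in this assay is a 1.4-fold lower number from compound 3 to compound 4 (0.15 log units; within the scatter) and no change beyond the scatter is anticipated. For compound 4 the estimate is 5 ug/mL with an expected range from 2 ug/mL to 12 ug/mL in this read-out.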

Compound 4, concentration for half-maximal effect: 4.3 ug/mL
Estimate against measurement, compound 4: 1.2-fold (0.07 log units) above, within the range that was stated.
By their numbers in this assay, from the lowest: compounds 1, 2, 4 and 3 (each within the scatter of the next).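

In this assay, the exchange of 2,6-dimethylphenyl for 1,3-thiazol-2-yl on a double-bonded chain carbon bound to a double-bonded chain carbon gives a 1.7-fold lower number from compound 3 to compound 4 (0.22 log units; within the scatter), so a five-membered aromatic ring with hetero atoms and fewer heavy atoms now joins the six-membered aromatic rings at this place without a step beyond the scatter. The comparisons with the other two groups read the same way, with a 1.1-fold higher number from compound 2 to compound 4 (0.05 log units; within the scatter) and a 1.2-fold higher number from compound 1 to compound 4 (0.08 log units; within the scatter), so the four groups at this place cannot be ranked in this assay, even though the entering group brings hydrogen-bond acceptors that 2,6-dimethylphenyl lacks. No supporting measurement bears on this result, so it stands as an observation without an explanation.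

The compounds shown leave open whether a group of a different kind at this place, such as an amine, a carboxylic acid or a longer alkyl chain in place of the aromatic ring, would give a step beyond the scatter. They also leave open whether a pyridine or a furan ring would stay within the scatter as 1,3-thiazol-2-yl does.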